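This account rests on a few compounds, and the source may have more. Where it says the series, first, only, none or still open, it means among the compounds named here.

Compound 1 `COc1ccc(CN(C(=O)CSc2nc3ccccc3s2)c2cc(OC)c(OC)c(OC)c2)cc1C` gives 6360 nM in a functional assay on MGC-803 cells (Homo sapiens) for antiproliferative activity, read by MTT assay, with a stated time of 48 h (on this read-out lower numbers stand for stronger inhibition and higher numbers for weaker inhibition), the lowest of the three numbers measured. Compound 2 `COc1cc(N(Cc2ccccc2)C(=O)CSc2nc3ccccc3s2)cc(OC)c1OC` gives 44300 nM, and compound 3 `COc1ccc(CN(C(=O)CSc2nc3ccccc3s2)c2cc(OC)c(OC)c(OC)c2)cc1OC` gives 34100 nM. The step of a 7.0-fold higher number from compound 1 to compound 2 (0.84 log units; beyond the scatter) and the step of a 5.4-fold higher number from compound 1 to compound 3 (0.73 log units; beyond the scatter) both lie beyond the scatter, whereas a 1.3-fold lower number from compound 2 to compound 3 (0.11 log units; within the scatter) lies within it.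

Compound 4 `COc1ccc(CN(C(=O)CSc2nc3ccccc3s2)c2cc(OC)c(OC)c(OC)c2)cc1N` differs from compound 1 by amino in place of methyl on an aromatic carbon: the methyl leaves and an amino enters, on an aromatic carbon ortho to a methoxy group and meta to a large group. Within the data shown here, the measured step that bears most closely on this is a 5.4-fold higher number from compound 1 to compound 3 (0.73 log units; beyond the scatter), the only change at the same aromatic carbon; the step of a 7.0-fold higher number from compound 1 to compound 2 (0.84 log units; beyond the scatter) removes that substituent together with the methoxy. Neither introduces an amino, so the data hold no direct test of that group. Both measured changes at this part of the core raised the number. A modest rise is therefore expected for compound 4 as well, a 3.5-fold higher number from compound 1 to compound 4 (0.54 log units; beyond the scatter). Compound 4 is estimated at 22000 nM, with a range from 6000 nM to 70000 nM.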

Compound 4, half-maximal inhibitory concentration: 84 nM
For compound 4 the middle estimate is 260-fold (2.42 log units) above the measured one; measured number below the stated range.
By their numbers in this assay, from the lowest: compound 4; then compound 1; then compounds 3 and 2 (each within the scatter of the next).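

Compound 4 shows that this aromatic carbon, ortho to a methoxy group, can move the number down as well as up: in this assay the earlier change at this carbon only raised it, whereas amino gives a 76-fold lower number from compound 1 to compound 4 (1.88 log units; beyond the scatter) in place of methyl and a 410-fold lower number from compound 3 to compound 4 (2.61 log units; beyond the scatter) in place of methoxy. The 3-amino-4-methoxyphenyl group also stands far from the unsubstituted phenyl, with a 530-fold lower number from compound 2 to compound 4 (2.72 log units; beyond the scatter), while the 3,4-dimethoxyphenyl group of compound 3 stayed within the scatter of that phenyl. Nothing shown here explains why the amino has so large an effect.

The compounds shown leave open whether a hydroxyl, a methylamino, a dimethylamino or an acetamido group on this carbon would keep the low number. They also leave open whether the amino gives the same gain with the methoxy beside it replaced by a hydrogen or an ethoxy.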